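Fluoro Added to the Bromophenyl Amide of Compound 2

A few compounds are considered here, and "the series" means these few. Any claim that something is new, unique, unknown or untested is made for them only; others in the source may bear on it.

Compound 1 `Nc1nn(Cc2cn(-c3ccc(O)c([N+](=O)[O-])c3)nn2)c2nc(-c3ccccc3)cc(C(F)(F)F)c12`: 36.3 ug/mL
Compound 2 `Nc1nn(Cc2cn(CC(=O)Nc3ccccc3Br)nn2)c2nc(-c3ccccc3)cc(C(F)(F)F)c12`: 95.3 ug/mL

Within the data shown here, in a functional assay on THP-1 cells (Homo sapiens) for cytotoxicity, read by MTT assay, with a stated time of 24 h (a lower number here means a stronger inhibitor, a higher number a weaker inhibitor), compound 2 gives 95.3 ug/mL, the higher of the two numbers measured so far. Among the measured compounds shown here, the one measured step, a 2.6-fold higher number from compound 1 to compound 2 (0.42 log units; beyond the scatter), concerns a different part of the molecule and does not bear on the change now considered. Compound 3 `Nc1nn(Cc2cn(CC(=O)Nc3ccc(F)cc3Br)nn2)c2nc(-c3ccccc3)cc(C(F)(F)F)c12` differs from compound 2 by fluoro in place of hydrogen on an aromatic carbon. For the measured compounds named here, no measured pair shows what such an addition does here, so the step of a 1.1-fold lower number from compound 2 to compound 3 (0.02 log units; within the scatter) is expected to stay within the scatter. Compound 3 is therefore estimated at 90 ug/mL, with a range from 45 ug/mL to 180 ug/mL.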

Compound 3, half-maximal inhibitory concentration: 65.6 ug/mL
Estimate against measurement, compound 3: 1.4-fold (0.14 log units) above, within the range that was stated.
By their numbers in this assay, from the lowest: compounds 1, 3 and 2 (each within the scatter of the next, the first and the last beyond it).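

In this assay, among these compounds, fluoro on this aromatic carbon, para to a large group, gives a 1.5-fold lower number from compound 2 to compound 3 (0.16 log units; within the scatter) and so stays inside the scatter, the first reading of this change. With fluoro present, the amide side chain no longer stands beyond the scatter from the 4-hydroxy-3-nitrophenyl group, as a 1.8-fold higher number from compound 1 to compound 3 (0.26 log units; within the scatter) shows for that exchange. No measured evidence bears on why these numbers fall as they do.

On these data alone, whether chloro, methoxy or an amine on this same carbon would also stay inside the scatter remains open. So does the effect of fluoro on the other carbons of this ring.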